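Swapping the 2,3,4-trimethoxyphenyl group of compound 2

A few compounds are considered here, and "the series" means these few. Any claim that something is new, unique, unknown or untested is made for them only; others in the source may bear on it.

In a functional assay on SW480 cells (Homo sapiens) for antiproliferative activity, read by sulforhodamine B assay, with a stated time of 48 h (a higher number here means a weaker inhibitor, a lower number a stronger inhibitor), compound 1 `COc1cccc(/C=C/C(=O)C(=Cc2ccc(O)c(F)c2)C(=O)/C=C/c2cccc(OC)c2OC)c1OC` gives 330 nM and compound 2 `COc1cccc(/C=C/C(=O)C(=Cc2ccc(OC)c(OC)c2OC)C(=O)/C=C/c2cccc(OC)c2OC)c1OC` gives 560 nM so the two stand within the scatter of each other. Compound 3 `COc1ccc(C=C(C(=O)/C=C/c2cccc(OC)c2OC)C(=O)/C=C/c2cccc(OC)c2OC)cc1O` has 3-hydroxy-4-methoxyphenyl in place of 2,3,4-trimethoxyphenyl on a double-bonded chain carbon bound to a double-bonded chain carbon. Among the measured compounds shown here, the one measured step bearing on this is a 1.7-fold higher number from compound 1 to compound 2 (0.23 log units; within the scatter) and it exchanges 3-fluoro-4-hydroxyphenyl and 2,3,4-trimethoxyphenyl at that same place. The expected change is a 1.4-fold lower number from compound 2 to compound 3 (0.15 log units; within the scatter) and so none beyond the scatter is anticipated. The estimate for compound 3 is 400 nM with an expected range from 150 nM to 1000 nM in this assay testing.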

Compound 3, half-maximal inhibitory concentration: 320 nM
Estimate against measurement, compound 3: 1.3-fold (0.10 log units) above; measured number inside the range.
By their numbers in this assay, from the lowest: compounds 3, 1 and 2 (each within the scatter of the next).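

At this place, on a double-bonded chain carbon bound to a double-bonded chain carbon, the exchange in this assay gives a 1.8-fold lower number from compound 2 to compound 3 (0.24 log units; within the scatter), and replacing 3-fluoro-4-hydroxyphenyl gives a 1.0-fold lower number from compound 1 to compound 3 (0.01 log units; within the scatter). All three groups shown here therefore stand within the scatter of one another, even though 3-hydroxy-4-methoxyphenyl has fewer heavy atoms than 2,3,4-trimethoxyphenyl and carries a hydrogen-bond donor that it lacks. No evidence is available to account for this result. Going by these compounds, whether an amine or a carboxylic acid on this aromatic ring would move the number beyond the scatter remains open.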